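Swapping the aryl group on the saturated ring carbon

A few compounds are considered here, and "the series" means these few. Any claim that something is new, unique, unknown or untested is made for them only; others in the source may bear on it.

Measured compounds:
Compound 1, `CN1C(=O)C(C2CC2)N(C)c2nc(Nc3ccc(S(N)(=O)=O)cc3)ncc21`, gives 136 nM in an assay on Sf9 cells for inhibition of serine/threonine-protein kinase 4 (Homo sapiens), read by luminescence and ADP-Glo, with a stated time of 1 h, in the presence of a further agent that is not named here; a lower number here means a stronger inhibitor, a higher number a weaker inhibitor.
Compound 2, `CC(C)C1C(=O)N(C)c2cnc(Nc3ccc(S(N)(=O)=O)cc3)nc2N1C`, gives 254 nM in this assay.
Compound 3, `COc1cccc(C2C(=O)N(C)c3cnc(Nc4ccc(S(N)(=O)=O)cc4)nc3N2C)c1`, gives 954 nM in this assay.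

Compound 3 stands highest of the three numbers, which means it is the weakest inhibitor of the set: its nearest neighbour is compound 2, and the steps that lead to it are a 7.0-fold higher number from compound 1 to compound 3 (0.85 log units; beyond the scatter) and a 3.8-fold higher number from compound 2 to compound 3 (0.57 log units; beyond the scatter). Both of these steps replace a small saturated group with the 3-methoxyphenyl group and both lie beyond the scatter, whereas the step between the two small groups, a 1.9-fold higher number from compound 1 to compound 2 (0.27 log units; within the scatter), does not.

Compound 4, `CN1C(=O)C(c2ccccc2Cl)N(C)c2nc(Nc3ccc(S(N)(=O)=O)cc3)ncc21`, is not yet measured. It differs from compound 3 in one place: 2-chlorophenyl in place of 3-methoxyphenyl on a saturated ring carbon. Within the data shown here, none of the measured steps exchanges one aryl group for another, so the measured steps only show that an aryl group at this position gives a higher number than cyclopropyl or isopropyl; they give no guidance on how a change of the substituent on that aryl ring shifts the number. Compound 4 is therefore expected to stay close to compound 3, with an expected step of a 1.1-fold lower number from compound 3 to compound 4 (0.03 log units; within the scatter) in this assay. For compound 4 the estimate is 900 nM, with a range from 300 nM to 2700 nM.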

Compound 4, half-maximal inhibitory concentration: 129 nM
Compound 4: the middle estimate sits 7.0-fold (0.84 log units) above what was measured; the measured number lies below the stated range.
By their numbers in this assay, from the lowest: compounds 4, 1 and 2 (each within the scatter of the next); then compound 3.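

In this assay an aryl group on this saturated ring carbon does not by itself go with a higher number, since putting 2-chlorophenyl in place of 3-methoxyphenyl gives a clear change (a 7.4-fold lower number from compound 3 to compound 4 (0.87 log units; beyond the scatter)). Among these compounds, the identity of the aryl group therefore counts at this position, which the earlier compounds, with only one aryl group among them, could not show. The 2-chlorophenyl compound also stands level with the small saturated groups (a 1.1-fold lower number from compound 1 to compound 4 (0.02 log units; within the scatter); a 2.0-fold lower number from compound 2 to compound 4 (0.29 log units; within the scatter)), so the earlier link between an aryl group and a higher number rests on compound 3 alone, and compound 4 goes against it. No measurement shown here explains the difference between the two aryl groups.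

On these data alone, this single change swaps both the substituent and its place on the ring, so a plain phenyl, a 2-methoxyphenyl or a 3-chlorophenyl would be needed to tell those two apart, and that question remains open. Also open, as far as these compounds go, is where the number would fall with an amine or a carboxylic acid on the aryl ring, or with a longer chain on this ring carbon.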